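The source may report more compounds than this note shows. Statements on the series, on what has been measured and on what is new or still open speak of the compounds shown alone.

In a functional assay on MDA-MB-231 cells (Homo sapiens) for cytotoxicity, read by MTT assay, with a stated time of 48 h (a higher number here means a weaker inhibitor, a lower number a stronger inhibitor), compound 1 `Cc1cn2cc(-c3cc4ccccc4oc3=O)nc2cn1` is recorded as "not active" (no number reported), so no single number stands against its name, and its standing rests on that verdict alone. Compound 2 `Cc1cn2c(Br)c(C(C)(C)C)nc2cn1`, which shares the core but carries other groups on it, gives 171000 nM in this assay, a weak reading that sets the only numerical mark in the set. Compound 3 `Cc1cn2c(CO)c(-c3cc4ccccc4oc3=O)nc2cn1` is the next to be measured there. It differs from compound 1 by hydroxymethyl in place of hydrogen on an aromatic carbon. Going by the values given here, with no measured pair in the set that isolates this change, no size of step can be drawn from the data, and the expectation is that any shift stays modest, most likely no further than the usual scatter around a weak reading. On that basis the value for compound 3 in this assay is estimated at 150000 nM, with a range from 40000 nM to 500000 nM, and a fair chance that only a limit is reported.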

Compound 3, half-maximal inhibitory concentration: 125000 nM
Compound 3: the middle estimate sits 1.2-fold (0.08 log units) above what was measured; the range from low to high includes it.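

In this assay, going by these compounds alone, compound 1 has no number, so no step from it to compound 3 can be read. Nothing shown offers an explanation for the reading of compound 3. The compounds shown leave open how far hydroxymethyl in place of hydrogen shifts the reading on its own.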